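The source may report more compounds than this note shows. Statements on the series, on what has been measured and on what is new or still open speak of the compounds shown alone.

Measured so far:
compound 1 `O=C(NCc1ccccc1)c1cn(-c2ccccc2)nc1-c1cccnc1` — in a functional assay on MCF7 cells (Homo sapiens) for cytotoxicity, read by MTT assay, with a stated time of 48 h; a higher number here means a weaker inhibitor, a lower number a stronger inhibitor: "nd(insoluble)" (no result reported)
compound 2 `COc1ccc(OC(=O)c2cn(-c3ccccc3)nc2-c2cccnc2)cc1` — > 100000 nM
compound 3 `O=C(NCc1ccccc1)c1cn(-c2ccccc2)nc1-c1ccncc1` — > 100000 nM

Compound 1 returned no result in this assay. In this assay compound 2 gives > 100000 nM, which is a limit of the assay and not a number. Compound 3 likewise gives > 100000 nM, again a limit only. Compound 3 therefore stands at the ceiling of what the assay reports, with no single number anywhere in the set to rank it against.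

Compound 4 `COc1ccc(OC(=O)c2cn(-c3ccccc3)nc2-c2ccncc2)cc1` differs from compound 3 by 4-methoxyphenoxy in place of benzylamino on a carbonyl carbon. Within the data shown here, no measured step covers this change. Because the limit of > 100000 nM in this assay, at which 2 of the 3 values shown sit, already holds both compounds with a numerical outcome, no shift beyond the scatter is expected from compound 3 to compound 4. Compound 4 is estimated at 200000 nM (60000 nM to 1000000 nM), an expected step that the limit leaves unreadable from compound 3 to compound 4.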

Compound 4, half-maximal inhibitory concentration: > 100000 nM
Compound 4 ended at the assay's limit; the forecaster's own chance of this, stated with the estimate: 85%; the middle value is on the limit's open side.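

The steps from compound 2 and from compound 3 to compound 4 cannot be read, because both ends of each step are limits: the limit of > 100000 nM in this assay, at which 3 of the 4 values shown sit.

The compounds shown leave open whether benzylamino versus 4-methoxyphenoxy, or pyridin-3-yl versus pyridin-4-yl, changes anything in this assay.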